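The compounds below may be only part of what the source reports. "The series", "measured", "known", "first", "only" and "open" are said of these compounds alone.

In a functional assay on MCF7 cells (Homo sapiens) for antiproliferative activity, read by MTT assay, with a stated time of 24 h (on this read-out higher numbers stand for weaker inhibition and lower numbers for stronger inhibition), compound 1 (`CCn1c(C(=O)NCCC(=O)OC)ccc1C(CC)(CC)c1ccc(OCS(=O)(=O)c2ccccc2)c(C)c1`) gives > 50000 nM which is a limit of the assay. Compound 2 (`CCn1c(C(=O)NCCNC(=O)OC(C)(C)C)ccc1C(CC)(CC)c1ccc(OCS(=O)(=O)c2ccccc2)c(C)c1`) gives > 50000 nM which is likewise a limit. Compound 3 (`CCn1c(C(=O)N[C@H](CO)C(C)C)ccc1C(CC)(CC)c1ccc(OCS(=O)(=O)c2ccccc2)c(C)c1`) gives 25500 nM and is the only one of the three with an actual number. As far as these compounds go, how far it stands from the other two cannot be fixed: the data give an at least 1.9-fold lower number from compound 1 to compound 3 (0.29 log units; that floor lies within the scatter) and an at least 1.9-fold lower number from compound 2 to compound 3 (0.29 log units; that floor lies within the scatter) as floors only, while a step that the two limits leave unreadable from compound 1 to compound 2 stays open.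

Compound 4 (`CCn1c(C(=O)N[C@@H](C)C(=O)O)ccc1C(CC)(CC)c1ccc(OCS(=O)(=O)c2ccccc2)c(C)c1`) carries 1-carboxyethyl in place of 1-(hydroxymethyl)-2-methylpropyl on an amide-type nitrogen. Among the measured compounds shown here, no measured step makes this exact exchange. The nearest guide is that compound 1 and compound 2, which carry other groups on that nitrogen, both end at the same ceiling, described as the limit of > 50000 nM in this assay, at which 2 of the 3 values shown sit, and so leaving compound 3 alone with a number. Losing the group of compound 3 is therefore expected to bring a small move toward weaker inhibition, and a report of only a limit would not surprise. In this assay the expected change is a 1.8-fold higher number from compound 3 to compound 4 (0.25 log units; within the scatter) and it may not clear the scatter. For compound 4 the estimate is 45000 nM with an expected range from 20000 nM to 100000 nM in this assay.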

Compound 4, half-maximal inhibitory concentration: 35500 nM
Beside the measured number, compound 4's estimate is 1.3-fold (0.10 log units) above it; measured number inside the range.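

In this assay, the amide-type nitrogen now carries a second group that returns an actual number, and with a 1.4-fold higher number from compound 3 to compound 4 (0.14 log units; within the scatter), 1-carboxyethyl and 1-(hydroxymethyl)-2-methylpropyl cannot be told apart at this position, even though the two groups share little beyond one defined stereocentre each. Against the other two compounds the data give only floors, an at least 1.4-fold lower number from compound 2 to compound 4 (0.14 log units; that floor lies within the scatter) and an at least 1.4-fold lower number from compound 1 to compound 4 (0.14 log units; that floor lies within the scatter), so the distance from those groups stays unfixed, and the step between compound 1 and compound 2 still cannot be read. Compound 1 and compound 2 each remain at a limit of the assay, not at a number: the limit of > 50000 nM in this assay, at which 2 of the 4 values shown sit.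

The compounds shown leave open whether the methyl ester of the 1-carboxyethyl group, a longer chain ending in a carboxylic acid, or a chain ending in an amine would stay with compound 3 and compound 4 or reach the limit, and whether the opposite configuration at the stereocentre would read the same. They also do not tell whether any group on this nitrogen can bring the number clearly lower than that of compound 3 and compound 4.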